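Mixed carboxyphenyl amide in the L-selectin series

The compounds below may be only part of what the source reports. "The series", "measured", "known", "first", "only" and "open" are said of these compounds alone.

Within the data shown here, compound 3 `CCCCCCCCCCOc1cc(OCCCCCCCCCC)cc(OCCCCCC(=O)N(c2cccc(C(=O)O)c2)c2cccc(C(=O)O)c2)c1` is one of three compounds measured in an assay on isolated protein for binding affinity to L-selectin (Homo sapiens), read by ELISA, tested at 500 uM; on this read-out higher numbers stand for more inhibition at the one concentration tested (going by the name of the read-out) and lower numbers for less inhibition. In this assay compound 3 gives 14%. Compound 2 `CCCCCCCCCCOc1cc(OCCCCCCCCCC)cc(OCCCCCC(=O)N(c2ccc(C(=O)OC)cc2)c2ccc(C(=O)OC)cc2)c1` gives 16%, within the scatter of compound 3. Compound 1 `O=C(O)c1ccc(N(C(=O)CCCCCBr)c2ccc(C(=O)O)cc2)cc1` gives 6%, also within the scatter of compound 3, so none of the three stands apart from the others.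

Compound 4 `CCCCCCCCCCOc1cc(OCCCCCCCCCC)cc(OCCCCCC(=O)N(c2ccc(C(=O)O)cc2)c2cccc(C(=O)O)c2)c1` differs from compound 3 in one place: 4-carboxyphenyl in place of 3-carboxyphenyl on an amide-type nitrogen. Among the measured compounds shown here, no measured pair shows this change on its own. Given that compound 2 and compound 3 sit within the scatter of each other, the step from compound 3 to compound 4 is expected to be a number 1 percentage points higher from compound 3 to compound 4 (within the scatter), not beyond the scatter in either direction. Compound 4 is thus estimated at 15%, with a range from 5% to 28%.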

Compound 4, a percentage reported as inhibition, at one concentration (the size of the read-out at that concentration, not a potency): 53%
Beside the measured number, compound 4's estimate is 38 percentage points below it; the measured number lies above the stated range.
By their numbers in this assay, from the lowest: compounds 1, 3 and 2 (each within the scatter of the next); then compound 4.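

Among these compounds, the change to 4-carboxyphenyl in place of 3-carboxyphenyl on the amide-type nitrogen gives a number 39 percentage points higher from compound 3 to compound 4 (beyond the scatter) in this assay and is the first step to stand beyond the scatter. Among the compounds shown here, the two compounds hold the same atoms, so the position of one carboxylic acid on that ring is enough to separate them, something the earlier compounds, with no pair differing in one place, could not show. No measurement at hand accounts for this step.

On these data alone, whether a second 4-carboxyphenyl, in place of the remaining 3-carboxyphenyl, adds to the step stays open. So does whether a tetrazole or a sulfonic acid can stand in for the carboxylic acid of the 4-carboxyphenyl group.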